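This account rests on a few compounds, and the source may have more. Where it says the series, first, only, none or still open, it means among the compounds named here.

Compound 1, `O=C(/C=C/c1coc2cc(O)ccc2c1=O)NCc1ccc(F)cc1`, gives in a functional assay on Huh-7 cells (Homo sapiens) for inhibition, read by MTT assay, with a stated time of 48 h (a higher number here means a weaker inhibitor, a lower number a stronger inhibitor), only a limit of the assay, > 100000 nM.
Compound 2, `COc1ccc2c(=O)c(/C=C/C(=O)Nc3ccc(Cl)cc3)coc2c1`, gives 37100 nM.
Compound 3, `COc1ccc(CNC(=O)/C=C/c2coc3cc(OC)ccc3c2=O)cc1`, gives 7570 nM.

Among the numbers shown, compound 3 stands lowest; the only measured step, a 4.9-fold lower number from compound 2 to compound 3 (0.69 log units; beyond the scatter), is modest. Compound 4, `COc1ccc(CNC(=O)/C=C/c2coc3cc(O)ccc3c2=O)cc1`, differs from compound 3 by hydrogen in place of methyl on an oxygen on an aromatic ring. Among the compounds with values here, no measured step covers this change. Compound 1 carries the same hydroxy on its core but also a different amide substituent, and its result is only a limit (the limit of > 100000 nM in this assay, at which 1 of the 3 values shown sits). On that basis compound 4 is expected to give a weaker result, with the step from compound 3 estimated as a 4.0-fold higher number from compound 3 to compound 4 (0.60 log units; beyond the scatter). The estimate for compound 4 is 30000 nM, within 8000 nM to 150000 nM.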

Compound 4, half-maximal inhibitory concentration: 8430 nM
Beside the measured number, compound 4's estimate is 3.6-fold (0.55 log units) above it; the measured number falls inside the stated range.
By their numbers in this assay, from the lowest: compounds 3 and 4 (each within the scatter of the next); then compound 2. At a limit, above all of these: compound 1.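

With the 4-methoxybenzyl amide held, hydrogen in place of methyl on an oxygen on an aromatic ring leaves this assay without a readable change: a 1.1-fold higher number from compound 3 to compound 4 (0.05 log units; within the scatter). With the hydroxy held, methoxy in place of fluoro on an aromatic carbon is a large step: an at least 11-fold lower number from compound 1 to compound 4 (1.07 log units; beyond the scatter). Its full size stays open, as compound 1 gives only a limit of the assay: the limit of > 100000 nM in this assay, at which 1 of the 4 values shown sits.

Going by these compounds, whether the methoxy-to-hydroxy result holds with other amide substituents remains open. So does whether a longer chain on that oxygen, or an amine or carboxylic acid in the place of the fluoro, would fit the same picture.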